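Methoxy added to the hydroxyphenyl member of the series

The source may report more compounds than this note shows. Statements on the series, on what has been measured and on what is new or still open speak of the compounds shown alone.

In a functional assay on HL-60 cells (Homo sapiens) for cytotoxicity, read by WST assay, with a stated time of 48 h (a higher number here means that more compound is needed for the effect, a lower number that less compound is needed), compound 2 (`O=C1OC[C@H](Cc2cccc(O)c2)[C@H]1Cc1ccc(Cl)c(Cl)c1`) gives 48000 nM as the highest of three numbers, with compound 1 (`O=C1OC[C@H](Cc2ccccc2)[C@H]1Cc1ccc(Cl)c(Cl)c1`) at 19000 nM and compound 3 (`O=C1OC[C@H](Cc2ccc(F)cc2)[C@H]1Cc1ccc(Cl)c(Cl)c1`) at 14000 nM in the same read-out. Compound 4 (`COc1ccc(C[C@H]2COC(=O)[C@@H]2Cc2ccc(Cl)c(Cl)c2)cc1O`) differs from compound 2 by methoxy in place of hydrogen on an aromatic carbon in one place: methoxy in place of hydrogen on an aromatic carbon, ortho to a hydroxy group and para to a large group. Within the data shown here, no measured step adds methoxy. The nearest evidence is single substitutions on the aromatic ring: a 2.5-fold higher number from compound 1 to compound 2 (0.40 log units; beyond the scatter) for hydroxy and a 1.4-fold lower number from compound 1 to compound 3 (0.13 log units; within the scatter) for fluoro, both modest or smaller. The step expected is therefore a 1.4-fold lower number from compound 2 to compound 4 (0.14 log units; within the scatter) and so none beyond the scatter. For compound 4 the estimated value is 35000 nM with 14000 nM to 90000 nM as the expected range.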

Compound 4, half-maximal effective concentration: 32000 nM
Estimate against measurement, compound 4: 1.1-fold (0.04 log units) above; the measured number falls inside the stated range.
By their numbers in this assay, from the lowest: compounds 3, 1, 4 and 2 (each within the scatter of the next, the first and the last beyond it).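

In this assay, methoxy on the ring of compound 2, ortho to a hydroxy group and para to a large group, gives a 1.5-fold lower number from compound 2 to compound 4 (0.18 log units; within the scatter), so the two compounds cannot be told apart in this read-out. The hydroxy step on the unsubstituted ring, a 2.5-fold higher number from compound 1 to compound 2 (0.40 log units; beyond the scatter), lies beyond the scatter, whereas this second ring substituent does not. Nothing available bears on the reason for this result.

From the compounds shown here alone, whether an amine or a carboxylic acid at this position, or a longer chain in place of methoxy, would stay within the scatter of compound 2 remains open. Also open, going by these compounds, is how methoxy reads at this position without the neighbouring hydroxy group.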